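A few compounds are considered here, and "the series" means these few. Any claim that something is new, unique, unknown or untested is made for them only; others in the source may bear on it.

Of the compounds shown here, three with a shared core have been measured in a functional assay on U-87MG ATCC cells for antiproliferative activity against U-87 MG (Homo sapiens), read by MTT assay, with a stated time of 48 h, tested at 10 uM; a lower number here means a stronger effect, a higher number a weaker effect of the compound at the concentration tested. Compound 1 `Cc1nc(-c2ccc(Cl)cc2)sc1C(=O)CSc1nc(-c2ccccc2)c(C#N)c(=O)[nH]1` gives 83.1%. Compound 2 `COc1ccc(-c2nc(C)c(C(=O)CSc3nc(-c4cccc(OC)c4)c(C#N)c(=O)[nH]3)s2)cc1` gives 66.7%. Compound 3 `COc1cccc(-c2nc(SCC(=O)c3sc(-c4ccccc4)nc3C)[nH]c(=O)c2C#N)c1` gives 90.2%, the highest of the three numbers, which in this read-out means the weakest effect; the gap to compound 1 lies within the scatter, while the gap to compound 2 lies beyond it. Going by the values given here, the only single-site step among the measured compounds is a number 23.5 percentage points higher from compound 2 to compound 3 (beyond the scatter), a modest rise.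

Compound 4 `Cc1nc(-c2ccccc2)sc1C(=O)CSc1nc(-c2ccc(Cl)c(Cl)c2)c(C#N)c(=O)[nH]1` differs from compound 3 by 3,4-dichlorophenyl in place of 3-methoxyphenyl on an aromatic carbon. This change sits on the other aromatic ring of the molecule than the methoxy removed in the measured step, so that step offers only a loose guide: it shows that swapping a small group on one aryl ring can move the number modestly. Compound 1, which also lacks a methoxy on the ring that changes here, sits within the scatter of compound 3. Among the compounds with values here, no measured step tests two chlorines against a methoxy, so no direction beyond the scatter is expected; a step of about a number 8.2 percentage points lower from compound 3 to compound 4 (within the scatter) is estimated, with a slight lean toward a lower number. Compound 4 is therefore expected to give 82%, somewhere between 62% and 96%.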

Compound 4, a percentage reported as activity, at one concentration (the size of the read-out at that concentration, not a potency): 92.5%
For compound 4 the middle estimate is 10.5 percentage points below the measured one, within the range that was stated.
By their numbers in this assay, from the lowest: compound 2; then compounds 1, 3 and 4 (each within the scatter of the next).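

Going by these compounds alone, the exchange of 3-methoxyphenyl for 3,4-dichlorophenyl, on an aromatic carbon of the six-membered ring with 2 nitrogen, is the first measured step at this position, and in this assay it gives a number 2.3 percentage points higher from compound 3 to compound 4 (within the scatter) without moving the number beyond the usual variation. The two groups have the same count of 8 heavy atoms, but the methoxy oxygen and its 1 hydrogen-bond acceptor leave while two chlorines enter, so this particular swap of ring substituents leaves the read-out unchanged within the scatter. The earlier single-site step, a number 23.5 percentage points higher from compound 2 to compound 3 (beyond the scatter), removed a methoxy from a different aryl ring, so the larger shift there cannot be carried over to this position, and no supporting data explain why the present exchange has so little effect.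

Still open, going by these compounds, is whether a group of a different kind at this position, such as an aminophenyl, a carboxylic acid on the phenyl ring or a longer alkyl chain in place of the aryl ring, would shift the number. On these data alone, it is also open whether 3,4-dichlorophenyl would behave the same way with the methoxy present on the other aryl ring.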